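Pentyloxy to propyl on the shared core of compound 1

The source may hold more compounds than are shown below. What is called first, only, known or untested is meant among the compounds shown, and "the series" means these compounds.

For the measured compounds named here, compound 1 `CCCCCOc1nc(N)c2nc(O)n(Cc3ccccc3)c2n1` is the only member of this small set with a measured number: in a functional assay (spleen, spleen) for activation, with Mus musculus as the target (on this read-out lower numbers stand for an effect already at smaller amounts and higher numbers for an effect only at larger amounts of compound), compound 1 gives 0.01 uM. Its two companions carry the same benzyl-bearing core but a smaller group at one aromatic carbon. Compound 2 `COc1nc2c(N)ncnc2n1Cc1ccccc1` reaches only the limit of this assay, > 10 uM. Compound 3 `CSc1nc2c(N)ncnc2n1Cc1ccccc1` likewise stops at a limit, > 10 uM. Going by the values given here, the one measured step, methylsulfanyl in place of methoxy on an aromatic carbon, a step that the two limits leave unreadable from compound 2 to compound 3, therefore cannot be read, and the only evidence on it is the limit of > 10 uM in this assay, at which 2 of the 3 values shown sit.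

Compound 4 `CCCc1nc(N)c2nc(O)n(Cc3ccccc3)c2n1` differs from compound 1 in a single place: propyl in place of pentyloxy on an aromatic carbon. Among the compounds with values here, no measured step concerns a pentyloxy or a propyl group, so nothing here tells how large a change in this assay to expect, nor its direction. The two limits of compound 2 and compound 3 show only that a methoxy or methylsulfanyl group in this position gives no number at all. Given this, a moderate loss is estimated, with wide uncertainty: compound 4 is expected to give 0.05 uM in this assay, within 0.005 uM to 0.5 uM, meaning an estimated step of a 5.0-fold higher number from compound 1 to compound 4 (0.70 log units; beyond the scatter).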

Compound 4, minimum effective concentration: 1 uM
For compound 4 the middle estimate is 20-fold (1.30 log units) below the measured one, and the stated range ends below it.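

For the compounds shown here, this is the only step in the set that can be read as a size: in this assay, putting propyl in place of pentyloxy on the shared core gives a 100-fold higher number from compound 1 to compound 4 (2.00 log units; beyond the scatter). This aromatic carbon, between two ring nitrogen atoms, is therefore not indifferent to what it carries, since a change at this one place, with the rest of the structure held the same, moves the read-out well beyond the usual scatter. Compound 2 and compound 3 differ from compound 1 in more than one place, so they could not show this, and the step between them cannot be read: the limit of > 10 uM in this assay, at which 2 of the 4 values shown sit.

Two things change together in this step, the chain gets shorter and the oxygen attached to the ring leaves, and the data do not tell which of them accounts for the loss; a pentyl or a propoxy group on the same core would separate the two. From the compounds shown here alone, how an amine or a longer chain such as heptyloxy would behave at this carbon in this assay also stays open.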